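Diphenylpyrazole sulfonamides: dihydroxy for dimethoxy on the aryl ring

The source may report more compounds than this note shows. Statements on the series, on what has been measured and on what is new or still open speak of the compounds shown alone.

Compound 1 `COc1ccc(OC)c(-c2cc(-c3ccccc3)nn2-c2ccc(S(N)(=O)=O)cc2)c1` is the reference of this pair of measured compounds. In a functional assay on cells (Cancer cell lines, Homo sapiens) for cytotoxicity, read by sulforhodamine B assay, with a stated time of 48 h (a lower number here means a stronger inhibitor of growth, a higher number a weaker inhibitor of growth), compound 1 gives 29800 nM. Among the measured compounds shown here, its only measured neighbour, compound 2 `COc1ccc(OC)c(-c2cc(-c3ccccc3)nn2-c2ccc(S(=O)(=O)NC(C)=O)cc2)c1`, gives 37700 nM in this assay, and the step of a 1.3-fold higher number from compound 1 to compound 2 (0.10 log units; within the scatter) shows that the two numbers cannot be told apart.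

Compound 3 `NS(=O)(=O)c1ccc(-n2nc(-c3ccccc3)cc2-c2cc(O)ccc2O)cc1` differs from compound 1 in one place: 2,5-dihydroxyphenyl in place of 2,5-dimethoxyphenyl on an aromatic carbon. For the measured compounds named here, no measured step touches this part of the structure; the single step known, from compound 1 to compound 2, concerns the sulfonamide nitrogen only and is within the scatter, so it gives no direction for the present change. With nothing to build on beyond compound 1 itself, the expectation for compound 3 in this assay is a number not beyond the scatter of compound 1, written as a 1.2-fold lower number from compound 1 to compound 3 (0.08 log units; within the scatter). The estimate for compound 3 is therefore 25000 nM, with a broad range from 6000 nM to 80000 nM reflecting the absence of any bearing step.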

Compound 3, concentration for total growth inhibition: 99300 nM
Compound 3: middle estimate off by 4.0-fold (0.60 log units), on the low side; the whole stated range lies below it.
By their numbers in this assay, from the lowest: compounds 1 and 2 (each within the scatter of the next); then compound 3.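

In this assay, the aryl group on the five-membered ring is the only site shown so far where a change moves the number beyond the scatter: 2,5-dihydroxyphenyl in place of 2,5-dimethoxyphenyl gives a 3.3-fold higher number from compound 1 to compound 3 (0.52 log units; beyond the scatter), a modest loss of growth inhibition. The change on the sulfonamide nitrogen, by contrast, stayed within the scatter, so this aryl group is the part of the structure that has so far shown a response. No measurement at hand bears on why the number rises at this position.

Going by these compounds, both oxygen substituents change together, so it remains open whether an aryl ring with one hydroxy and one methoxy group would fall with compound 1 or with compound 3. Also open, on these data alone, is whether an ethoxy group or an amine on this ring would move the number further in either direction.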